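Iodo to hydrogen step on the shared core, second instance

The source may hold more compounds than are shown below. What is called first, only, known or untested is meant among the compounds shown, and "the series" means these compounds.

Measured compounds:
Compound 1 `O=C1C(=O)N(CCCCCn2cc(COc3cc(=O)oc4ccccc34)nn2)c2ccc(I)cc21` gives 45% in a functional assay on THP-1 cells (Homo sapiens) for inhibition, read by sulforhodamine B assay, with a stated time of 48 h, tested at 50 uM; on this read-out lower numbers stand for less inhibition of growth and higher numbers for more inhibition of growth at the one concentration tested.
Compound 2 `O=C1C(=O)N(CCCn2cc(COc3cc(=O)oc4ccccc34)nn2)c2ccccc21` gives 93% in this assay.
Compound 3 `O=C1C(=O)N(CCCn2cc(COc3cc(=O)oc4ccccc34)nn2)c2ccc(I)cc21` gives 67% in this assay.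

Compound 1 stands lowest of the three, with compound 3 nearest and compound 2 furthest. The change from compound 3 to compound 2 is hydrogen in place of iodo on an aromatic carbon; it made a number 26 percentage points higher from compound 3 to compound 2 (beyond the scatter) in this assay. Compound 4 `O=C1C(=O)N(CCCCCn2cc(COc3cc(=O)oc4ccccc34)nn2)c2ccccc21` arises from compound 1 by the same change, (hydrogen in place of iodo on an aromatic carbon). How the core of compound 1 differs from the core of compound 3 is not broken down here. Because the same change gave a number 26 percentage points higher from compound 3 to compound 2 (beyond the scatter), a step of similar size, a number 26 percentage points higher from compound 1 to compound 4 (beyond the scatter), is expected from compound 1 to compound 4 in this assay. Compound 4 is therefore estimated at 71%, expected to fall between 55% and 87%.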

Compound 4, percent growth inhibition at one concentration: 69%
Beside the measured number, compound 4's estimate is 2 percentage points above it, within the range that was stated.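

Hydrogen in place of iodo on the aromatic carbon gives a number 24 percentage points higher from compound 1 to compound 4 (beyond the scatter) in this assay. On the two cores shown, the change carries over with a step of similar size: the same change on two cores in this assay, a number 26 percentage points higher (beyond the scatter) from compound 3 to compound 2 and a number 24 percentage points higher (beyond the scatter) from compound 1 to compound 4, 2 percentage points apart, within the scatter of two such steps

Among these compounds, this rests on only two pairs, read at a single concentration in one cell line, and it does not show that the step would hold on other cores or in other assays. The compounds shown leave open how bromo, chloro or an amine on the same aromatic carbon would compare with iodo and hydrogen. They also leave open whether the step persists with a longer chain on the core.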